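Trimming a tert-butyl Carbamate to Isopropyl

This account rests on a few compounds, and the source may have more. Where it says the series, first, only, none or still open, it means among the compounds named here.

Compound 1, `CC(C)OC(=O)N1CCC(O[C@H]2CC[C@H](Oc3ccc(S(C)(=O)=O)nc3)CC2)CC1`: in a functional assay on isolated protein for agonist activity at Glucose-dependent insulinotropic receptor (Homo sapiens), read by HTRF and cAMP accumulation (a higher number here means a larger maximal response, a lower number a smaller maximal response), compound 1 gives 101%.
Compound 2, `CC(C)(C)OC(=O)N1CCC(O[C@H]2CC[C@H](Oc3cnc(S(C)(=O)=O)cn3)CC2)CC1`: in this assay compound 2 gives 110%.

Only these two compounds have been measured so far. The numbers of compound 2 and compound 1 differ by an amount that lies within the usual scatter of repeated measurements, so neither can be set above the other on this evidence; compound 2 simply sits at the same level as compound 1.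

Compound 3, `CC(C)OC(=O)N1CCC(O[C@H]2CC[C@H](Oc3cnc(S(C)(=O)=O)cn3)CC2)CC1`, has not yet been measured. It differs from compound 2 in one place: hydrogen in place of methyl on a saturated chain carbon bound to an oxygen next to a carbonyl group and two saturated chain carbons. Because compound 1, which carries the isopropoxycarbonyl group, gives 101%, no step beyond the scatter is expected in this assay from this change in either direction. The estimate for compound 3 is therefore 105%, within the range 88% to 122%, which amounts to an expected step of a number 5 percentage points lower from compound 2 to compound 3 (within the scatter).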

Compound 3, largest response reached (Emax), in percent of the reference or control that the assay uses: 110%
Compound 3: the middle estimate sits 5 percentage points below what was measured; low and high end bracket the measured number.
By their numbers in this assay, from the lowest: compounds 1, 2 and 3 (each within the scatter of the next).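

In this assay the change from tert-butoxycarbonyl to isopropoxycarbonyl gives no change at the digits printed from compound 2 to compound 3 (within the scatter) and thus shows that this methyl can leave without a step beyond the scatter in the maximal response. Putting 5-(methylsulfonyl)pyrazin-2-yl in place of 6-(methylsulfonyl)pyridin-3-yl, with the isopropoxycarbonyl group held fixed, gives a number 9 percentage points higher from compound 1 to compound 3 (within the scatter) and so this exchange on the oxygen also leaves the response at the same level. Nothing available offers an explanation for either result.

Going by these compounds, whether the response holds when the end of the carbamate is trimmed further, to a methoxycarbonyl group, or when a cyclopropyl group takes the place of isopropyl, stays open. The largest response alone also leaves open how much of each compound is needed to reach it.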